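The compounds below may be only part of what the source reports. "The series", "measured", "known", "first", "only" and "open" are said of these compounds alone.

In a functional assay on GBM3 cells (Homo sapiens) for antiproliferative activity, read by WST assay, with a stated time of 72 h (a higher number here means a weaker inhibitor, a lower number a stronger inhibitor), compound 1 `O=C(Nc1cccc(Cl)c1)Nc1cc2ncncc2cc1OCc1ccccc1Cl` gives 2800 nM while compound 2 `O=C(Nc1ccc(Cl)c(Cl)c1)Nc1cc2ncncc2cc1OCc1cccc(F)c1` gives 2000 nM and compound 3 `O=C(Nc1cccc(F)c1)Nc1cc2ncncc2cc1OCc1ccccc1Cl` gives 2400 nM so all three lie within the scatter of one another, and compound 1 cannot be told apart from the other two. Compound 4 `O=C(Nc1cccc(Cl)c1)Nc1cc2ncncc2cc1OCc1cccc(Cl)c1` has the same atoms as compound 1, joined differently. The change is 3-chlorophenyl in place of 2-chlorophenyl on a saturated chain carbon bound to an oxygen on an aromatic ring and it turns (2-chlorobenzyl)oxy into (3-chlorobenzyl)oxy on the shared core. For the measured compounds named here, no measured step makes this move. Compound 2 differs from compound 1 in more than one place, so it offers no clean comparison. Going by the values given here, the only measured step is a 1.2-fold lower number from compound 1 to compound 3 (0.07 log units; within the scatter) with fluoro in place of chloro on an aromatic carbon, a different change that bears on this one only loosely. Given that small step, no shift beyond the scatter is expected in this assay in either direction. The estimated step is a 1.1-fold lower number from compound 1 to compound 4 (0.05 log units; within the scatter) and it is expected to be too small to count as a real change. For compound 4 the estimate is 2500 nM with an expected range from 1200 nM to 5000 nM in repeated measurements.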

Compound 4, half-maximal inhibitory concentration: 3500 nM
The estimate for compound 4 lay 1.4-fold (0.15 log units) below the measured number; measured number inside the range.
By their numbers in this assay, from the lowest: compounds 2, 3, 1 and 4 (each within the scatter of the next).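

In this assay, swapping 2-chlorophenyl for 3-chlorophenyl on a saturated chain carbon bound to an oxygen on an aromatic ring gives a 1.3-fold higher number from compound 1 to compound 4 (0.10 log units; within the scatter). This is the only clean step shown at this group, since a 1.2-fold lower number from compound 1 to compound 3 (0.07 log units; within the scatter) involves fluoro in place of chloro elsewhere on compound 1. Among these two compounds, then, moving the chlorine from 2-chlorobenzyl to 3-chlorobenzyl produces no real change in the number, and nothing available explains this result.

Open, from the compounds shown here alone, is whether this group tolerates a real change of substituent: an amine or a carboxylic acid in place of the chlorine could give a step beyond the scatter, or none. A single chlorine move also says nothing about how a longer chain between the oxygen and the ring would behave.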